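Adding a Methyl to the Phenyl of Compound 2

This account rests on a few compounds, and the source may have more. Where it says the series, first, only, none or still open, it means among the compounds named here.

Compound 1 `COc1ccc(-n2nc(-c3ccc4ccccc4c3)nc2N2C(=O)COC23C=CC(=O)C=C3)cc1`: 60 nM
Compound 2 `O=C1C=CC2(C=C1)OCC(=O)N2c1nc(-c2ccc3ccccc3c2)nn1-c1ccccc1`: 70 nM

Both compounds were tested in a functional assay on MDA-MB-231 cells (Homo sapiens) for antiproliferative activity, with a stated time of 5 days; on this read-out higher numbers stand for weaker inhibition and lower numbers for stronger inhibition. Compound 1 gives 60 nM there, and compound 2 gives 70 nM. Within the data shown here, compound 2 therefore holds the higher of the two numbers, but the only measured step, a 1.2-fold higher number from compound 1 to compound 2 (0.07 log units; within the scatter), is within the scatter, so the two compounds cannot be told apart on this read-out.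

Compound 3 `Cc1ccc(-n2nc(-c3ccc4ccccc4c3)nc2N2C(=O)COC23C=CC(=O)C=C3)cc1` is the next compound. It differs from compound 2 by methyl in place of hydrogen on an aromatic carbon.

Among the measured compounds shown here, only one measured step bears on this change, and only loosely: a 1.2-fold higher number from compound 1 to compound 2 (0.07 log units; within the scatter) swapped methoxy for hydrogen on the same aromatic carbon and left the read-out essentially unchanged. For the measured compounds named here, no measured compound carries a methyl at that carbon, so the expectation rests on that single step. With one small group removed without effect, a small group entering is expected to behave the same way, and the step of a 1.1-fold lower number from compound 2 to compound 3 (0.03 log units; within the scatter) is expected to stay within the scatter. Compound 3 is estimated at 65 nM, with a range of 30 nM to 150 nM.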

Compound 3, half-maximal inhibitory concentration: 30 nM
Beside the measured number, compound 3's estimate is 2.2-fold (0.34 log units) above it, and the stated range covers the measured number.
By their numbers in this assay, from the lowest: compounds 3, 1 and 2 (each within the scatter of the next, the first and the last beyond it).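

Going from phenyl to 4-methylphenyl gives a 2.3-fold lower number from compound 2 to compound 3 (0.37 log units; beyond the scatter) in this assay, the first change at this position that moves the number beyond the scatter, so what sits on this carbon can matter, although the step is modest. Methyl in place of methoxy gives a 2.0-fold lower number from compound 1 to compound 3 (0.30 log units; within the scatter), which stays within the scatter, so the methyl compound and the methoxy compound cannot be told apart, and the gain for methyl shows only against the hydrogen of compound 2. No measurement here explains why methyl and hydrogen differ at this carbon.

As far as these compounds go, whether an ethyl, a longer chain, an amine or a carboxylic acid on this same carbon would lower the number further, leave it unchanged or raise it remains open. From the compounds shown here alone, the methyl also appears in only this one place, para to a large group, so what it would do elsewhere on the ring remains unknown.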